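Methyl to Methoxy on the Outer Ring

The source may hold more compounds than are shown below. What is called first, only, known or untested is meant among the compounds shown, and "the series" means these compounds.

Compound 1 `O=C(O)C[C@@H]1CCCN1c1ccc(Oc2ccc(Cl)cc2Cl)cc1`: 3200 nM in a functional assay on cells for agonist activity at Free fatty acid receptor 1 (Mus musculus), read by FLIPR and calcium flux, with a stated time of 100 s; a higher number here means that more compound is needed for the effect, a lower number that less compound is needed.
Compound 2 `Cc1ccc(Oc2ccc(N3CCC[C@H]3CC(=O)O)cc2)cc1`: > 33000 nM in this assay, a limit of the assay rather than a number.

Among the compounds with values here, only one step links these two measured compounds. Exchanging 2,4-dichlorophenyl for 4-methylphenyl on the oxygen gave an at least 10-fold higher number from compound 1 to compound 2 (1.01 log units; beyond the scatter). On these data alone, compound 2 thus sits at the limit of > 33000 nM in this assay, at which 1 of the 2 values shown sits, and how far beyond that edge its true value lies is unknown.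

Compound 3 `COc1ccc(Oc2ccc(N3CCC[C@H]3CC(=O)O)cc2)cc1` differs from compound 2 by methoxy in place of methyl on an aromatic carbon. Within the data shown here, no measured pair compares methyl with methoxy on this ring, so nothing in the measured steps speaks for or against a change, and the expectation must rest on the position of compound 2 alone. Compound 3 is therefore expected to give 50000 nM in this assay, with a range of 15000 nM to 200000 nM. This expected a step that the limit leaves unreadable from compound 2 to compound 3 amounts to no step beyond the scatter, and the most likely outcome is that compound 3 is again reported only as a limit of the assay.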

Compound 3, half-maximal effective concentration: > 33000 nM
Compound 3 was reported as a limit; the forecaster's own chance of this, stated with the estimate: 70%; the middle value does not contradict the limit.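

Compound 3 gives > 33000 nM in this assay, which is a limit of the assay and not a number. Exchanging the 2,4-dichlorophenyl on the oxygen for 4-methoxyphenyl gave an at least 10-fold higher number from compound 1 to compound 3 (1.01 log units; beyond the scatter), so a second group with a single substituent on the outer ring, after the 4-methylphenyl of compound 2, also falls well short of compound 1 in this test. The change from methyl to methoxy itself cannot be read, and neither compound can be ranked against the other, as the two share one edge of the measurable range: the limit of > 33000 nM in this assay, at which 2 of the 3 values shown sit.

The compounds shown leave open how much of the lower number of compound 1 belongs to the chlorines, since its outer ring differs from the others by more than one atom and no ring with a single chlorine stands among them. On these data alone, it also remains open whether another group in the place of the methyl or methoxy, such as a trifluoromethyl or an ethyl, would bring the number back within the measurable range.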